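This account rests on a few compounds, and the source may have more. Where it says the series, first, only, none or still open, it means among the compounds named here.

Compounds measured:
compound 1 `CCCCCOC1=C(C(=O)c2ccccc2)C(c2ccc(Br)cc2)N(CCCn2ccnc2)C1=O`: 7290 nM
compound 2 `O=C(C1=C(Nc2ccccc2)C(=O)N(CCCn2ccnc2)C1c1ccc(Br)cc1)c1ccccc1`: 24100 nM

In a functional assay on A549 cells (Homo sapiens) for antiproliferative activity, read by MTT assay, with a stated time of 72 h (a lower number here means a stronger inhibitor, a higher number a weaker inhibitor), compound 2 gives 24100 nM, the higher of the two numbers, while compound 1 gives 7290 nM. Among the measured compounds shown here, the one measured step, a 3.3-fold higher number from compound 1 to compound 2 (0.52 log units; beyond the scatter), puts anilino in place of pentyloxy on the shared core and ends in compound 2 as the weaker of the pair.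

Compound 3 `CCOc1ccc(NC2=C(C(=O)c3ccccc3)C(c3ccc(Br)cc3)N(CCCn3ccnc3)C2=O)cc1` keeps the anilino of compound 2 and differs from it by ethoxy in place of hydrogen on an aromatic carbon. For the measured compounds named here, no measured step bears on this change: the step from compound 1 to compound 2 concerns the group on the ring carbon of the core, not a substituent on the aromatic ring of the anilino. With nothing in the data to point either way, the step is expected to stay within the scatter, a 1.2-fold lower number from compound 2 to compound 3 (0.08 log units; within the scatter). Compound 3 is therefore estimated at 20000 nM, with a range from 7000 nM to 60000 nM.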

Compound 3, half-maximal inhibitory concentration: 20200 nM
For compound 3 the middle estimate is 1.0-fold (0.00 log units) below the measured one; the range from low to high includes it.
By their numbers in this assay, from the lowest: compound 1; then compounds 3 and 2 (each within the scatter of the next).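

In this assay, ethoxy on an aromatic carbon para to a large group gives a 1.2-fold lower number from compound 2 to compound 3 (0.08 log units; within the scatter), so this place on the phenyl of the anilino takes an ethoxy without a shift beyond the scatter. With the ethoxy in place, the group on the double-bonded ring carbon still separates the compounds, with a 2.8-fold higher number from compound 1 to compound 3 (0.44 log units; beyond the scatter) for (4-ethoxyphenyl)amino in place of pentyloxy. Nothing in the data at hand gives a reason for either step.

The compounds shown leave open whether a carboxylic acid, a dimethylamino group or a longer chain such as pentyloxy at this same place on the phenyl would move the number beyond the scatter. They also leave open how a simple alkylamine, such as pentylamino, would read on the double-bonded ring carbon.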